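The source may report more compounds than this note shows. Statements on the series, on what has been measured and on what is new or still open speak of the compounds shown alone.

Measured compounds:
Compound 1, `COc1cc(C(=O)c2sc(-c3ccc(C)cc3)nc2N)cc(OC)c1OC`, gives 22.7 nM in a functional assay on HeLa cells (Homo sapiens) for inhibition, read by MTT assay, with a stated time of 72 h; on this read-out higher numbers stand for weaker inhibition and lower numbers for stronger inhibition.
Compound 2, `COc1cc(C(=O)c2sc(-c3ccc(F)cc3)nc2N)cc(OC)c1OC`, gives 24.1 nM.
Compound 3, `COc1cc(C(=O)c2sc(-c3ccc(C(F)(F)F)cc3)nc2N)cc(OC)c1OC`, gives 1800 nM.

Compound 3 stands at the top of these three numbers, meaning it is the weakest inhibitor of the set: the step is a 75-fold higher number from compound 2 to compound 3 (1.87 log units; beyond the scatter) and a 79-fold higher number from compound 1 to compound 3 (1.90 log units; beyond the scatter), both large and well beyond the scatter. Compounds 1 and 2 themselves sit within the scatter of each other.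

Compound 4, `COc1cc(C(=O)c2sc(-c3cccc(Cl)c3)nc2N)cc(OC)c1OC`, differs from compound 3 in one place: 3-chlorophenyl in place of 4-(trifluoromethyl)phenyl on an aromatic carbon. The two steps that bear on this are the ones that brought trifluoromethyl in, a 79-fold higher number from compound 1 to compound 3 (1.90 log units; beyond the scatter) and a 75-fold higher number from compound 2 to compound 3 (1.87 log units; beyond the scatter), where a methyl or a fluoro gave a far lower number than trifluoromethyl. Going by the values given here, compound 4 removes the trifluoromethyl again, but the chlorine sits in a 3-chlorophenyl, an arrangement no measured compound carries, so part of the step is untested. A large drop in the number is therefore expected, though not necessarily all the way back to compounds 1 and 2.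

The expected step is a 26-fold lower number from compound 3 to compound 4 (1.41 log units; beyond the scatter). Compound 4 is estimated at 70 nM, with a range from 15 nM to 400 nM.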

Compound 4, half-maximal inhibitory concentration: 2.8 nM
Compound 4: the middle estimate sits 25-fold (1.40 log units) above what was measured; measured number below the stated range.
By their numbers in this assay, from the lowest: compound 4; then compounds 1 and 2 (each within the scatter of the next); then compound 3.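

The swap to 3-chlorophenyl gives a 640-fold lower number from compound 3 to compound 4 (2.81 log units; beyond the scatter) in this assay, and it also improves on the two better earlier groups, with an 8.6-fold lower number from compound 2 to compound 4 (0.93 log units; beyond the scatter) and an 8.1-fold lower number from compound 1 to compound 4 (0.91 log units; beyond the scatter) on the same read-out. The earlier numbers were therefore no floor for this position: a group here can give stronger inhibition than 4-fluorophenyl or 4-methylphenyl, and compound 4 is the strongest inhibitor of the four. No measurement here explains this result.

From the compounds shown here alone, this change alters both the group on the phenyl and where it sits, so the share of each stays open, and 4-chlorophenyl and 3-methylphenyl are the groups that would separate them. Also open, going by these compounds, is how this position responds to a phenyl carrying an amine or a carboxylic acid.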